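Adding a Second Methoxy Group to Compound 1

The source may report more compounds than this note shows. Statements on the series, on what has been measured and on what is new or still open speak of the compounds shown alone.

Of the compounds shown here, two have been tested in a functional assay on HCT-116 cells (Homo sapiens) for cytotoxicity, read by sulforhodamine B assay, with a stated time of 48 h, tested at 100 uM; on this read-out higher numbers stand for a weaker effect at the one concentration tested and lower numbers for a stronger effect. Compound 1, `COc1ccc(-c2cc(/C=C/C(=O)c3ccc(N)cc3)[nH]n2)cc1`, gives -15% in this assay, the higher of the two numbers recorded and therefore the weaker effect. Compound 2, `COc1cc(-c2cc(/C=C/C(=O)c3ccc(F)c(F)c3)[nH]n2)cc(OC)c1OC`, gives -52% in this assay, a number that lies beyond the usual scatter from that of compound 1. Compound 2 differs from compound 1 in more than one place, so its result cannot be tied to any single change.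

Compound 3, `COc1ccc(-c2cc(/C=C/C(=O)c3ccc(N)cc3)[nH]n2)cc1OC`, has not yet been measured. It differs from compound 1 by one change: methoxy in place of hydrogen on an aromatic carbon, placed on an aromatic carbon of a six-membered aromatic ring of carbon only, ortho to a methoxy group and meta to a large group.

Within the data shown here, no directly comparable pair is available, so the expectation rests on the two numbers alone. Compound 3 is expected to show a modest move toward a stronger effect, a step of a number 10 percentage points lower from compound 1 to compound 3 (within the scatter), which is within the scatter. Compound 3 is therefore estimated at -25%, with a range from -50% to 0%.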

Compound 3, a percentage reported as activity, at one concentration (the size of the read-out at that concentration, not a potency): -89%
For compound 3 the middle estimate is 64 percentage points above the measured one, outside the stated range (below it).
By their numbers in this assay, from the lowest: compound 3; then compound 2; then compound 1.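

In this assay, methoxy in place of hydrogen on an aromatic carbon, ortho to a methoxy group and meta to a large group, gives a number 74 percentage points lower from compound 1 to compound 3 (beyond the scatter), which on this read-out means a much stronger effect. This is the first change in the series that can be read on its own, as the two earlier compounds differ in more than one place and could tie their gap to no single group, so this one position on the ring is now shown to have a large influence on the result. Nothing available so far bears on why one added methoxy group makes a step of this size.

From the compounds shown here alone, whether the methoxy group itself is needed at this carbon stays open, as a hydroxyl, an ethoxy or a fluorine in the same place could give a similar step or a very different one. Among these compounds, the series also holds only this one example of the change, so it remains open whether the same step would appear if the amine of compound 1 were replaced by a fluorine or a nitrile.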